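Fluoro for Methoxy on Two Related Bis-ester Cores

The source may report more compounds than this note shows. Statements on the series, on what has been measured and on what is new or still open speak of the compounds shown alone.

Compound 1 `COc1cccc(OC(=O)c2ccccc2O)c1OC(=O)c1ccccc1O` and compound 2 `O=C(Oc1cccc(F)c1OC(=O)c1ccccc1O)c1ccccc1O` share one core, and compound 3 `COc1cccc(OC(=O)c2ccc(O)cc2)c1OC(=O)c1ccc(O)cc1` and compound 4 `O=C(Oc1cccc(F)c1OC(=O)c1ccc(O)cc1)c1ccc(O)cc1` share another; the two cores are built from the same atoms joined differently, and the difference between them is not broken down here. In a functional assay on NCI-H1299 cells (Homo sapiens) for inhibition, read by scintillation counting, with a stated time of 30 min, tested at 30 uM (a lower number here means less inhibition, a higher number more inhibition at the concentration tested (going by the name of the read-out)), compound 1 gives 50.5%, and compound 2 gives 51%. Compound 3 gives 86.5% in this assay, which stands beyond the scatter above both compound 1 and compound 2.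

The change from compound 1 to compound 2 is fluoro in place of methoxy on an aromatic carbon, and it made a step of a number 0.5 percentage points higher from compound 1 to compound 2 (within the scatter). The same change, (fluoro in place of methoxy on an aromatic carbon), leads from compound 3 to compound 4; the surroundings of the place are described in the same words for both pairs, so it is the same change.

Because the measured instance of this change, a number 0.5 percentage points higher from compound 1 to compound 2 (within the scatter), stays within the scatter, compound 4 is expected to come out close to compound 3 in this assay, and the step of a number 1.5 percentage points lower from compound 3 to compound 4 (within the scatter) is estimated to be small. Compound 4 is therefore expected to give about 85%, with a plausible range from 72% to 96%. This rests on a single prior instance of the change, so the expectation carries the width of the usual scatter rather than any firmer trend.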

Compound 4, a percentage reported as inhibition, at one concentration (the size of the read-out at that concentration, not a potency): 92.6%
For compound 4 the middle estimate is 7.6 percentage points below the measured one, and the stated range covers the measured number.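

In this assay, among the compounds shown here, fluoro in place of methoxy on an aromatic carbon gave a number 6.1 percentage points higher from compound 3 to compound 4 (within the scatter), so on this second core, as on the first, the swap produced no step that stands out from the scatter. Set side by side, the two steps give no sign that the core alters the outcome of this change, and in this small set it carried from one core to the other without a detectable difference: the same change on two cores in this assay, a number 0.5 percentage points higher (within the scatter) from compound 1 to compound 2 and a number 6.1 percentage points higher (within the scatter) from compound 3 to compound 4, 5.6 percentage points apart, within the scatter of two such steps. This does not show that the change is without any effect or that the two cores respond identically. A small real step could lie hidden within the scatter. Two pairs read at a single concentration say nothing about potency or about how the change would behave on a third core.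

The compounds shown leave open how other groups would read at this same place, such as chloro, an amine, a nitrile or a longer chain in the form of an ethoxy or propoxy group. They also leave open whether the result would hold if an amide took the place of the ester links on either core.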